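The compounds below may be only part of what the source reports. "The series", "measured", "known", "first", "only" and "open" are said of these compounds alone.

Compound 1 `O=c1nc2ccccn2cc1Cc1ccc(F)cc1C(F)(F)F` and compound 3 `O=c1nc2ccc(Cl)cn2cc1Cc1ccc(F)cc1C(F)(F)F` share one core; compound 3 differs only by chloro in place of hydrogen on an aromatic carbon. In a functional assay on SK-N-SH cells (Homo sapiens) for cytotoxicity, read by MTT assay, with a stated time of 24 h (a higher number here means a weaker inhibitor, a lower number a stronger inhibitor), compound 1 gives 8690 nM, while compound 3 gives 106000 nM, so that change brought a 12-fold higher number from compound 1 to compound 3 (1.09 log units; beyond the scatter). Compound 2 `CC1(C)OC2O[C@@H](Cc3cn4ccccc4nc3=O)C(OCc3ccccc3)C2O1` rests on another core, and how its core differs from that of compound 1 is not broken down here. In this assay compound 2 reaches only a limit of the assay, > 1000000 nM. Compound 4 `CC1(C)OC2O[C@@H](Cc3cn4cc(Cl)ccc4nc3=O)C(OCc3ccccc3)C2O1` is compound 2 carrying the same change, (chloro in place of hydrogen on an aromatic carbon). For compound 4 the expected step is a step that the limit leaves unreadable from compound 2 to compound 4, resting on a 12-fold higher number from compound 1 to compound 3 (1.09 log units; beyond the scatter) and on compound 2 already sitting at the limit of > 1000000 nM in this assay, at which 1 of the 3 values shown sits. Compound 4 is therefore estimated at 3000000 nM, most likely again reported only as a limit.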

Compound 4, half-maximal inhibitory concentration: > 1000000 nM
Compound 4: a limit, no number; the forecaster's own chance of this, stated with the estimate: 90%; the middle value lies beyond the limit too.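

Compound 2 and compound 4 are both reported only as limits, not numbers, so no step can be read between them. As far as these compounds go, whether chloro in place of hydrogen raises the number on their core, as it does on the core of compound 1, stays open.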